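An Aryl Amide in Place of the Urea

A few compounds are considered here, and "the series" means these few. Any claim that something is new, unique, unknown or untested is made for them only; others in the source may bear on it.

Going by the values given here, compound 2 `O=C(Nc1ccc(Cl)cc1)Nc1c(C(O)(C(F)(F)F)C(F)(F)F)ccc2ccccc12` gives 276 nM in an assay on LtK cells with ATP-sensitive inward rectifier potassium channel 11 (Homo sapiens) as the target (on this read-out higher numbers stand for an effect only at larger amounts of compound and lower numbers for an effect already at smaller amounts), the lowest of the two numbers so far; compound 1 `CCC(CC)C(=O)Nc1c(C(O)(C(F)(F)F)C(F)(F)F)ccc2ccccc12` gives 4340 nM. Among the compounds with values here, the only measured step, a 16-fold lower number from compound 1 to compound 2 (1.20 log units; beyond the scatter), swapped pentan-3-yl for (4-chlorophenyl)amino on a carbonyl carbon. Compound 3 `Cc1ccccc1C(=O)Nc1c(C(O)(C(F)(F)F)C(F)(F)F)ccc2ccccc12` carries the change (2-methylphenyl in place of (4-chlorophenyl)amino on a carbonyl carbon). That step bears on the change only in part, since the aromatic ring and the hydrogen-bond donor entered together there. Compound 3 is therefore expected to give 1500 nM, with a range from 400 nM to 6000 nM. The step expected is then a 5.4-fold higher number from compound 2 to compound 3 (0.74 log units; beyond the scatter).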

Compound 3, half-maximal effective concentration: 5550 nM
Beside the measured number, compound 3's estimate is 3.7-fold (0.57 log units) below it; measured number inside the range.
By their numbers in this assay, from the lowest: compound 2; then compounds 1 and 3 (each within the scatter of the next).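

Putting 2-methylphenyl in place of (4-chlorophenyl)amino on this carbonyl carbon gives a 20-fold higher number from compound 2 to compound 3 (1.30 log units; beyond the scatter) and so undoes the gain seen earlier. With a 1.3-fold higher number from compound 1 to compound 3 (0.11 log units; within the scatter) as well, an aromatic ring on the carbonyl carbon is clearly not enough to give a number as low as that of compound 2. Nothing measured here explains the step.

Going by these compounds, the nitrogen, the chlorine and the methyl all differ in this swap, so their separate shares stay open. A cyclohexylamino group on the carbonyl carbon would show what the nitrogen does without an aromatic ring.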